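Imidazole to Triazole on a Cyclohexylphenyl Anilide

The compounds below may be only part of what the source reports. "The series", "measured", "known", "first", "only" and "open" are said of these compounds alone.

Of the compounds shown here, two sharing a cyclohexylphenyl unit have been measured in an ADME assay on MDCK-MDR1 cells (Canis lupus familiaris) for permeability, in the apical to basolateral direction, with a stated time of 180 min; on this read-out lower numbers stand for lower permeability and higher numbers for higher permeability. Compound 1 `O=C(c1ccc(C2CCCCC2)cc1)N1CC(O)C1` carries a hydroxyazetidine amide and in this assay compound 1 gives 26 10^-6 cm/s. Compound 2 `O=C(Cn1ccnc1)Nc1ccc(C2CCCCC2)cc1` is an anilide and in this assay compound 2 gives 11.1 10^-6 cm/s, the lower of the two numbers; the gap to compound 1 is beyond the usual scatter. Compound 3 `CC(C(=O)Nc1ccc(C2CCCCC2)cc1)n1cncn1` has not yet been measured and differs from compound 2 in one place: 1-(1H-1,2,4-triazol-1-yl)ethyl in place of (1H-imidazol-1-yl)methyl on a carbonyl carbon. Among the measured compounds shown here, no step between measured compounds covers this change, so the expectation rests on compound 2 alone. The step from compound 2 to compound 3 is expected to be small, a 1.3-fold higher number from compound 2 to compound 3 (0.10 log units; within the scatter), upward if anything, and not clearly beyond the scatter. In this assay compound 3 is therefore estimated at 14 10^-6 cm/s, within a range from 6 10^-6 cm/s to 32 10^-6 cm/s.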

Compound 3, apparent permeability: 29.5 10^-6 cm/s
Estimate against measurement, compound 3: 2.1-fold (0.32 log units) below, and the stated range covers the measured number.
By their numbers in this assay, from the lowest: compound 2; then compounds 1 and 3 (each within the scatter of the next).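

The position on the carbonyl carbon of the anilide proves responsive in this assay: placing 1-(1H-1,2,4-triazol-1-yl)ethyl there instead of (1H-imidazol-1-yl)methyl gives a 2.7-fold higher number from compound 2 to compound 3 (0.42 log units; beyond the scatter), the first single-place step available in this series. The step joins two differences in one change, since the ring goes from two hetero atoms to three while the group grows from six heavy atoms to seven, and the measured number cannot divide the step between them. Nothing measured here offers an explanation for the rise.

As far as these compounds go, it remains open how much of the step belongs to the ring and how much to the added carbon, which 1-(1H-imidazol-1-yl)ethyl or (1H-1,2,4-triazol-1-yl)methyl would help to separate. From the compounds shown here alone, how an amine or a carboxylic acid would fare at this place also remains open.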